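The compounds below may be only part of what the source reports. "The series", "measured", "known", "first", "only" and "open" are said of these compounds alone.

Working notes on the series, read in a functional assay on HL-60 cells (Homo sapiens) for inhibition, read by MTT assay, with a stated time of 72 h; on this read-out lower numbers stand for stronger inhibition and higher numbers for weaker inhibition. The compounds share one core and differ in the group on an amine nitrogen in a ring. Compound 1 `Cc1nc(-c2ccccc2)c(C(=O)N2CCN(c3cccc(Cl)c3Cl)CC2)o1` gives 133 nM, compound 2 `Cc1nc(-c2ccccc2)c(C(=O)N2CCN(c3cccc(C(N)=O)c3)CC2)o1` gives 71 nM and compound 3 `Cc1nc(-c2ccccc2)c(C(=O)N2CCN(c3cccc(C(F)(F)F)c3)CC2)o1` gives 153 nM. Compound 3 thus stands level with compound 1 and apart from compound 2 only, at a 2.2-fold higher number from compound 2 to compound 3 (0.33 log units; beyond the scatter).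

The next change leads to compound 4 `Cc1nc(-c2ccccc2)c(C(=O)N2CCN(c3ccc(Cl)c(Cl)c3)CC2)o1`: 3,4-dichlorophenyl in place of 3-(trifluoromethyl)phenyl on an amine nitrogen in a ring. In words, 3,4-dichlorophenyl takes the place of 3-(trifluoromethyl)phenyl.

The closest guide is a 1.2-fold higher number from compound 1 to compound 3 (0.06 log units; within the scatter), which joins a dichlorophenyl compound to compound 3. The steps involving carbamoyl, such as a 1.9-fold lower number from compound 1 to compound 2 (0.27 log units; within the scatter), bear less directly, since neither group in this change carries it. No step beyond the scatter is therefore expected in this assay.

The estimate is a 1.1-fold lower number from compound 3 to compound 4 (0.04 log units; within the scatter), an expected step of no real size. For compound 4 the expected value is 140 nM, with an estimated range of 65 nM to 300 nM.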

Compound 4, half-maximal inhibitory concentration: 124 nM
Beside the measured number, compound 4's estimate is 1.1-fold (0.05 log units) above it, within the range that was stated.
By their numbers in this assay, from the lowest: compounds 2, 4, 1 and 3 (each within the scatter of the next, the first and the last beyond it).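

At this position, this assay does not tell the 2,3-dichlorophenyl and 3,4-dichlorophenyl groups apart, with a 1.1-fold lower number from compound 1 to compound 4 (0.03 log units; within the scatter) as the step, and 3,4-dichlorophenyl is likewise not told apart from 3-(trifluoromethyl)phenyl, with a 1.2-fold lower number from compound 3 to compound 4 (0.09 log units; within the scatter) as the step. The 3-carbamoylphenyl group also stays within the scatter of the new group, at a 1.7-fold higher number from compound 2 to compound 4 (0.24 log units; within the scatter), whereas a 2.2-fold higher number from compound 2 to compound 3 (0.33 log units; beyond the scatter) lies just beyond it, so the only gap beyond the scatter does not extend to every non-carbamoyl group shown. No measurement is available that would account for any of these steps.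

Going by these compounds, whether a carboxylic acid or an aminomethyl group on the phenyl ring would give a step clearly beyond the scatter stays open. The same holds for a cyclohexyl group on the amine nitrogen in place of the aromatic ring.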